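The compounds below may be only part of what the source reports. "The series", "measured", "known", "first", "only" and "open" are said of these compounds alone.

Measured so far in an assay on NIH3T3 cells for binding affinity to melatonin receptor type 1A (Homo sapiens); a lower number here means a stronger inhibitor, a higher number a weaker inhibitor:
- compound 1, `CCC(=O)NCCCc1cccc2c1C[C@@H](CCCCc1ccccc1)O2`: 1 nM
- compound 2, `CCCC(=O)NCCCc1cccc2c1C[C@@H](CCCCc1ccccc1)O2`: 2 nM
- compound 3, `CC(C)C(=O)NC[C@@H]1C[C@H]1c1cccc2c1C[C@@H](CCCCc1ccccc1)O2`: 6 nM

Compound 2 stands second highest of the three numbers in this assay. Its nearest neighbour is compound 1: a 2.0-fold higher number from compound 1 to compound 2 (0.30 log units; within the scatter), a difference that cannot be told from repeat-measurement noise. Compound 3 gives the highest number of the three and lies beyond the scatter from compound 2, but compound 3 also carries a different linker to the amide nitrogen, so its value cannot be tied to the acyl group alone.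

Compound 4, `CC(C)C(=O)NCCCc1cccc2c1C[C@@H](CCCCc1ccccc1)O2`, is not yet measured. It differs from compound 2 in one place: isopropyl in place of propyl on a carbonyl carbon. Among the measured compounds shown here, the only measured step that touches the same acyl region is a 2.0-fold higher number from compound 1 to compound 2 (0.30 log units; within the scatter), and it stayed within the scatter. For the measured compounds named here, no measured pair isolates the branching of the acyl group itself, so the expectation rests on that single step and on the spread of the three values. Compound 4 is expected to stay close to compound 2, with an estimated step of a 1.3-fold higher number from compound 2 to compound 4 (0.10 log units; within the scatter), meaning no change beyond the scatter. The estimate for compound 4 in this assay is 2.5 nM, with a range of 0.8 nM to 7 nM.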

Compound 4, inhibition constant: 4 nM
Compound 4: the middle estimate sits 1.6-fold (0.20 log units) below what was measured, and the stated range covers the measured number.
By their numbers in this assay, from the lowest: compounds 1, 2, 4 and 3 (each within the scatter of the next, the first and the last beyond it).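

In this assay, isopropyl in place of propyl on a carbonyl carbon gives a 2.0-fold higher number from compound 2 to compound 4 (0.30 log units; within the scatter); the two groups have the same heavy-atom count, and this rearrangement of the acyl chain cannot be told from repeat-measurement noise. Methyl in place of hydrogen on a saturated chain carbon bound to a carbonyl carbon and a saturated chain carbon gives a 4.0-fold higher number from compound 1 to compound 4 (0.60 log units; beyond the scatter), the first step in the acyl region to lie beyond the scatter, though it is a modest one. No supporting data accompany either step, and no reason for them can be offered from this series.

The compounds shown leave open how the acyl position responds to a tert-butyl group, a cyclopropyl group, a longer chain such as pentyl, or an acyl chain carrying an amine or a carboxylic acid. Also open is what the linker to the amide nitrogen contributes across different acyl groups, as compound 3 is the only compound shown with a different linker.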